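The source may report more compounds than this note shows. Statements on the series, on what has been measured and on what is new or still open speak of the compounds shown alone.

Of the compounds shown here, three sharing one core have been measured in an assay on isolated protein for inhibition of 2-Hydroxyacid oxidase 1 (Homo sapiens), with stated times of 30 min and 15 min (on this read-out lower numbers stand for stronger inhibition and higher numbers for weaker inhibition), and a fourth now awaits the same test. Compound 1 `CC(C)c1coc(-c2cccc(CNc3ccc4[nH]nc(C(=O)O)c4c3)c2O)n1` carries a 4-isopropyl-1,3-oxazol-2-yl group and in this assay gives 87 nM. Compound 2 `CC(C)c1csc(-c2cccc(CNc3ccc4[nH]nc(C(=O)O)c4c3)c2O)n1` carries a 4-isopropyl-1,3-thiazol-2-yl group instead and gives 65 nM; the step of a 1.3-fold lower number from compound 1 to compound 2 (0.13 log units; within the scatter) is within the scatter. Compound 3 `CN(C)C(=O)c1cccc(CNc2ccc3[nH]nc(C(=O)O)c3c2)c1O` carries a dimethylcarbamoyl group at that position. For compound 3 this assay reports only a limit, > 30000 nM, so no exact number is known; it sits at the limit of > 30000 nM in this assay, at which 1 of the 3 values shown sits. The steps of an at least 340-fold higher number from compound 1 to compound 3 (2.53 log units; beyond the scatter) and an at least 460-fold higher number from compound 2 to compound 3 (2.66 log units; beyond the scatter) are both large.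

Compound 4 `CC(C)c1noc(-c2cccc(CNc3ccc4[nH]nc(C(=O)O)c4c3)c2O)n1` is the next candidate. Relative to compound 3 the change is 3-isopropyl-1,2,4-oxadiazol-5-yl in place of dimethylcarbamoyl on an aromatic carbon. This reverses the kind of change seen in those two large steps: a dimethylcarbamoyl group gives way to a five-membered aromatic ring bearing an isopropyl group, as in compound 1 and compound 2. A large drop in the number is therefore expected, of about an at least 200-fold lower number from compound 3 to compound 4 (2.30 log units; beyond the scatter). Compound 4 is estimated to give 150 nM in this assay, with a likely range from 40 nM to 600 nM.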

Compound 4, half-maximal inhibitory concentration: 47 nM
Compound 4: the middle estimate sits 3.2-fold (0.50 log units) above what was measured; low and high end bracket the measured number.
By their numbers in this assay, from the lowest: compounds 4, 2 and 1 (each within the scatter of the next). At a limit, above all of these: compound 3.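

In this assay, the position on an aromatic carbon ortho to a hydroxy group now takes a third five-membered aromatic ring bearing an isopropyl group, and the large gap to the dimethylcarbamoyl group appears again: an at least 630-fold lower number from compound 3 to compound 4 (2.80 log units; beyond the scatter). The new ring has a different set of hetero atoms, and its isopropyl group is numbered differently, yet the steps to the two earlier rings, a 1.4-fold lower number from compound 2 to compound 4 (0.14 log units; within the scatter) and a 1.9-fold lower number from compound 1 to compound 4 (0.27 log units; within the scatter), both lie within the scatter, so across compound 1, compound 2 and compound 4 these three rings cannot be told apart in this read-out. The figure for compound 3 is a limit and not an exact number, so the large step gives only a minimum size: the limit of > 30000 nM in this assay, at which 1 of the 4 values shown sits.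

Every ring shown carries an isopropyl group, so these compounds cannot separate what the ring contributes from what the isopropyl group contributes. A methyl group or a tert-butyl group on the same ring, or an unsubstituted phenyl ring at this position, remains an open case.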